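Nitro-indole carboxylic acids tested for pannexin-1 inhibition

The source may report more compounds than this note shows. Statements on the series, on what has been measured and on what is new or still open speak of the compounds shown alone.

Measured compounds:
compound 1 `O=C(O)c1cn(Cc2ccccc2)c2ccc([N+](=O)[O-])cc12` gives 65%
compound 2 `O=C(O)c1ccc(Cn2cc(C(=O)O)c3cc([N+](=O)[O-])ccc32)cc1` gives 54%
compound 3 `O=C(O)c1cc2cc([N+](=O)[O-])ccc2n1Cc1ccccc1` gives 51.3%

All three were run in an assay on cells (Oocyte) for inhibition of pannexin-1 (Mus musculus), read by voltage clamp, tested at 50 uM, in the presence of a further agent that is not named here; a lower number here means less inhibition, a higher number more inhibition at the concentration tested (going by the name of the read-out). Compound 1 and compound 2 differ only by carboxy in place of hydrogen on an aromatic carbon, and this change gives a number 11 percentage points lower from compound 1 to compound 2 (beyond the scatter). Compound 3 shares its atoms with compound 1 but joins them differently; the difference between the two cores is not broken down here. In this assay compound 3 stands close to compound 2, within the scatter, and is separated from compound 1 by a gap beyond the scatter.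

Compound 4 `O=C(O)c1ccc(Cn2c(C(=O)O)cc3cc([N+](=O)[O-])ccc32)cc1` is not yet measured. It differs from compound 3 by carboxy in place of hydrogen on an aromatic carbon, which is the same change as that from compound 1 to compound 2; the surroundings of the place are described in the same words in both cases. If that change behaves alike on the core of compound 3, the step in this assay is expected to be a number 11.3 percentage points lower from compound 3 to compound 4 (beyond the scatter), alongside the earlier step from compound 1 to compound 2. The expectation rests on a single pair, so the range is wide. Compound 4 is estimated at 40%, between 27% and 53%.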

Compound 4, a percentage reported as inhibition, at one concentration (the size of the read-out at that concentration, not a potency): 61%
The estimate for compound 4 lay 21 percentage points below the measured number, and the stated range ends below it.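

In this assay, carboxy in place of hydrogen on an aromatic carbon, para to a large group, gives a number 9.7 percentage points higher from compound 3 to compound 4 (within the scatter). The change therefore does not carry over as a fixed step between the two cores: the same change on two cores in this assay, a number 11 percentage points lower (beyond the scatter) from compound 1 to compound 2 and a number 9.7 percentage points higher (within the scatter) from compound 3 to compound 4, 20.7 percentage points apart, beyond the scatter of two such steps This shows that, for these two pairs at a single concentration, the outcome of the change depends on the core; with one pair per core, it gives neither a reason for the difference nor a rule for any further core.

The compounds shown carry only hydrogen or carboxy at this place on the benzyl ring, so it remains open how a methyl ester, a primary amide or an amine there would read on either core. The nitro group is also the same throughout, which leaves open whether a nitrile or an amine in its place would alter the difference between the two cores.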